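This account rests on a few compounds, and the source may have more. Where it says the series, first, only, none or still open, it means among the compounds named here.

Compound 1 `Cc1ccccc1-c1nn(-c2cccc(Cl)c2)cc1CNCCN1CCN(C)CC1`: 16000 nM
Compound 2 `Cc1ccccc1-c1nn(Cc2ccccc2)cc1CNCCN1CCN(C)CC1`: > 20000 nM

In an ADME assay on Huh-7 cells (Homo sapiens) for cytotoxicity (a lower number here means that less compound is tolerated, a higher number that more compound is tolerated), compound 1 gives 16000 nM. For compound 2 the assay reports only a limit, > 20000 nM, so compound 2 stands at the edge of what can be measured here. That limit is the limit of > 20000 nM in this assay, at which 1 of the 2 values shown sits. Between the two lies an at least 1.2-fold higher number from compound 1 to compound 2 (0.09 log units; that floor lies within the scatter), a step too small on its own to separate them. Compound 3 `Cc1ccccc1-c1nn(-c2ccc(OC(F)(F)F)cc2)cc1CNCCN1CCN(C)CC1` differs from compound 2 in one place: 4-(trifluoromethoxy)phenyl in place of benzyl on an aromatic nitrogen. Within the data shown here, the only measured step that bears on this is the one from compound 1 to compound 2, which replaced an aromatic ring on that aromatic nitrogen with a benzyl group and changed little. Compound 3 puts an aromatic ring back in that place, so the number is expected to move back toward that of compound 1 or stay at the limit. The expected step is an at least 1.5-fold lower number from compound 2 to compound 3 (0.18 log units; that floor lies within the scatter). Compound 3 is estimated at 13000 nM, with a likely range from 5000 nM to 25000 nM.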

Compound 3, half-maximal cytotoxic concentration: 17000 nM
Compound 3: the middle estimate sits 1.3-fold (0.12 log units) below what was measured; the measured number falls inside the stated range.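

In this assay, swapping 3-chlorophenyl for 4-(trifluoromethoxy)phenyl on the aromatic nitrogen leaves compound 3 within the scatter of compound 1 (a 1.1-fold higher number from compound 1 to compound 3 (0.03 log units; within the scatter)), even though the new group brings oxygen, fluorine and a hydrogen-bond acceptor. Two differently substituted phenyl rings at this position therefore read alike, which a single ring could not show. Set against the benzyl group, the comparison (an at least 1.1-fold lower number from compound 2 to compound 3 (0.07 log units; that floor lies within the scatter)) also stays within the scatter, and it gives only a floor because compound 2 is a limit: the limit of > 20000 nM in this assay, at which 1 of the 3 values shown sits. Whether benzyl truly differs from a directly attached phenyl ring therefore remains unsettled. Also open, on these data alone, is whether an amine or a carboxylic acid on that ring, or a longer chain carrying it, would move the number beyond the scatter.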